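From Cyclohexyl to Pentan-3-yl at a Limit

This account rests on a few compounds, and the source may have more. Where it says the series, first, only, none or still open, it means among the compounds named here.

In a functional assay on ACHN cells (Homo sapiens) for antiproliferative activity, read by sulforhodamine B assay (a lower number here means a stronger inhibitor of growth, a higher number a weaker inhibitor of growth), compound 1 `CCCCCCOc1cccc(O)c1C(=O)/C=C/c1ccc(O)cc1` gives > 30000 nM, which is a limit and not a number. Compound 2 `O=C(/C=C/c1ccc(O)cc1)c1c(O)cccc1OCC1CCCCC1` also gives only a limit, > 30000 nM, so its place on the scale has no exact reading. Going by the values given here, the one measured step is a step that the two limits leave unreadable from compound 1 to compound 2, made by putting cyclohexyl in place of pentyl. The evidence so far is the limit of > 30000 nM in this assay, at which 2 of the 2 values shown sit.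

Compound 3 `CCC(CC)COc1cccc(O)c1C(=O)/C=C/c1ccc(O)cc1` changes compound 2 in one place: pentan-3-yl in place of cyclohexyl on a saturated chain carbon bound to an oxygen on an aromatic ring. Pentan-3-yl stands in place of cyclohexyl, on a saturated chain carbon bound to an oxygen on an aromatic ring.

With no readable step to carry over, no step beyond the scatter is expected in this assay, in either direction. The expected result is a number no higher from compound 2 to compound 3 (the limit leaves the size open). For compound 3 the estimated value is 30000 nM, with an expected range from 12000 nM to 60000 nM.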

Compound 3, concentration for 50% growth inhibition: 3370 nM
Beside the measured number, compound 3's estimate is 8.9-fold (0.95 log units) above it; measured number outside the range, below it.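

The position, a saturated chain carbon bound to an oxygen on an aromatic ring, now proves able to move the read-out in this assay: with pentan-3-yl there, the series gives its first exact number. Putting pentan-3-yl in place of cyclohexyl gives an at least 8.9-fold lower number from compound 2 to compound 3 (0.94 log units; beyond the scatter), and putting it in place of pentyl gives an at least 8.9-fold lower number from compound 1 to compound 3 (0.94 log units; beyond the scatter). Compound 1 and compound 2 still stand only at a limit: the limit of > 30000 nM in this assay, at which 2 of the 3 values shown sit.

From the compounds shown here alone, with a single exact value, the true size of both steps stays open, and no trend across these groups can be drawn. Going by these compounds, whether a longer chain, or an amine at the end of the chain, would keep this growth inhibition, lose it or strengthen it also remains open.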